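The compounds below may be only part of what the source reports. "The series", "measured", "known", "first", "only" and "open" are said of these compounds alone.

Compound 1 `CC1=C(N2CC2)C(=O)C(C(C)COC(N)=O)=C(N2CC2)C1=O` gives 5.31 in a functional assay on L1210 cells (Mus musculus), with a stated time of 1 days (on this read-out lower numbers stand for lower potency and higher numbers for higher potency (the scale is a negative logarithm)), the highest of the three numbers. Compound 3 `COCCOC(COC(N)=O)C1=C(N2CC2)C(=O)C(C)=C(N2CC2)C1=O` gives 4.96, and compound 2 `CCC1=C(N2CC2)C(=O)C(CC)=C(N2CC2)C1=O` gives 4.79. For the measured compounds named here, the one step from compound 1 that is measured alone, a number 0.35 log units lower from compound 1 to compound 3 (beyond the scatter), shows a modest loss, though it touches a different position. Compound 4 `CC1=C(N2CC2)C(=O)C(C(C)C)=C(N2CC2)C1=O` differs from compound 1 as follows: hydrogen in place of carbamoyloxy on a saturated chain carbon, two bonds along the chain from a double-bonded ring carbon. Going by the values given here, no measured step covers removing the carbamoyloxy group; compound 2 also lacks it and stands lowest, but differs from compound 1 in more than one place. A loss beyond the scatter is therefore expected, and compound 4 is estimated at 4.85, within 4.4 to 5.3, a step of a number 0.46 log units lower from compound 1 to compound 4 (beyond the scatter).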

Compound 4, logarithm of the reciprocal of the active concentration, log(1/C): 4.69
Compound 4: the middle estimate sits 0.16 log units above what was measured; measured number inside the range.
By their numbers in this assay, from the lowest: compounds 4, 2 and 3 (each within the scatter of the next); then compound 1.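

In this assay, for the compounds shown here, hydrogen in place of carbamoyloxy on a saturated chain carbon gives a number 0.62 log units lower from compound 1 to compound 4 (beyond the scatter) and is the first single change to isolate this group. The carbamoyloxy group therefore contributes to the higher number of compound 1, at least on this core and at this place. Nothing available explains the loss.

The compounds shown leave open whether a hydroxyl or an acetoxy group at this place would keep the number of compound 1, or whether only the intact carbamoyloxy group does.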